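The compounds below may be only part of what the source reports. "The series", "measured", "known", "first", "only" and "open" are said of these compounds alone.

All four compounds share one core, seen in compound 1 `CCOCc1nnc(N2C[C@@H]3C[C@]3(c3ccc(F)cc3Cl)C2)n1-c1ccc(OC)nc1`, which in a functional assay on HEK293 cells for antagonist activity at Vasopressin V1b receptor (Homo sapiens), read by calcium flux, with a stated time of 10 min (on this read-out lower numbers stand for stronger inhibition and higher numbers for weaker inhibition), gives 28000 nM. Compound 2 `COc1ccc(-n2c(COCCF)nnc2N2C[C@@H]3C[C@]3(c3ccc(F)cc3Cl)C2)cn1` carries fluoro in place of hydrogen on a saturated chain carbon, two bonds along the chain from an oxygen on a saturated carbon, and in this assay compound 2 gives 24500 nM; the step of a 1.1-fold lower number from compound 1 to compound 2 (0.06 log units; within the scatter) shows that this exchange made no difference beyond the scatter. Compound 3 `COc1ccc(-n2c(COC3CCOCC3)nnc2N2C[C@@H]3C[C@]3(c3ccc(F)cc3Cl)C2)cn1` bears an oxan-4-yl group on that oxygen, but in this assay compound 3 gives "not determined" (no result reported), so compound 3 stands nowhere on the scale and only compound 1 and compound 2 give a footing. Compound 4 `COc1ccc(-n2c(CO[C@H]3CCOC3)nnc2N2C[C@@H]3C[C@]3(c3ccc(F)cc3Cl)C2)cn1` differs from compound 3 by oxolan-3-yl in place of oxan-4-yl on an oxygen on a saturated carbon. Going by the values given here, no measured step concerns such an exchange of one saturated ring for another; the only step at hand touches a different part of the chain and lay within the scatter. With nothing pointing up or down, and with both measured compounds of this series weak, compound 4 is expected to land near them. Compound 4 is estimated at 25000 nM, with a range from 8000 nM to 80000 nM.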

Compound 4, half-maximal inhibitory concentration: 56700 nM
Compound 4: middle estimate off by 2.3-fold (0.36 log units), on the low side; measured number inside the range.
By their numbers in this assay, from the lowest: compounds 2 and 1 (each within the scatter of the next); then compound 4.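

In this assay, the ethyl and 2-fluoroethyl groups on this oxygen could not be told apart, but replacing either with a ring does register: oxolan-3-yl in place of 2-fluoroethyl gives (a 2.3-fold higher number from compound 2 to compound 4 (0.36 log units; beyond the scatter)), and oxolan-3-yl in place of ethyl gives (a 2.0-fold higher number from compound 1 to compound 4 (0.31 log units; beyond the scatter)). This is the first change shown at this position that goes beyond the scatter, so the group on the oxygen can affect the read-out, here modestly and towards weaker inhibition, although a single measured ring cannot establish a pattern for rings in general. Nothing shown here explains this rise.

Compound 3 has no number, so the step from it to compound 4 cannot be read, and the exchange of oxan-4-yl for oxolan-3-yl remains unresolved. Also open, going by these compounds, is how the read-out would respond to the other stereocentre arrangement of the oxolan-3-yl group, to a longer chain such as butyl, or to an amine such as piperidin-4-yl on this oxygen.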